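The source may report more compounds than this note shows. Statements on the series, on what has been measured and on what is new or still open speak of the compounds shown alone.

Measured so far in a toxicity assay on HEK-293T cells (Homo sapiens) for cytotoxicity, read by CCK-8 assay, with a stated time of 48 h; a lower number here means that less compound is tolerated, a higher number that more compound is tolerated:
compound 1 `Cn1cc(SCc2nnc(S)n2-c2c(Cl)cccc2Cl)c2ccccc21` gives > 100000 nM, a limit of the assay.
compound 2 `Cn1cc(SCc2nnc(SCc3ccccc3)n2-c2c(Cl)cccc2Cl)c2ccccc21` gives > 100000 nM, again a limit.
compound 3 `Cn1cc(SCc2nnc(SCc3cc(C(F)(F)F)ccc3Cl)n2-c2c(Cl)cccc2Cl)c2ccccc21` gives 53800 nM.

Compound 2 thus stands only at a limit in this assay, with no number of its own, as the limit of > 100000 nM in this assay, at which 2 of the 3 values shown sit, shows. Compound 4 `Cn1cc(SCc2nnc(SCc3ccc(Cl)cc3C(F)(F)F)n2-c2c(Cl)cccc2Cl)c2ccccc21` differs from it by 4-chloro-2-(trifluoromethyl)phenyl in place of phenyl on a saturated chain carbon bound to a sulfur. The closest measured step is an at least 1.8-fold lower number from compound 2 to compound 3 (0.26 log units; that floor lies within the scatter), and an at least 1.8-fold lower number from compound 1 to compound 3 (0.26 log units; that floor lies within the scatter) points the same way, while a step that the two limits leave unreadable from compound 1 to compound 2. Both readable steps are floors lying within the scatter, so for compound 4 the expectation in this assay is a step of about an at least 1.4-fold lower number from compound 2 to compound 4 (0.15 log units; that floor lies within the scatter), downward if anything, and not clearly beyond the scatter. Compound 4 is estimated at 70000 nM, between 30000 nM and 100000 nM, with a fair chance that only a limit is reported.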

Compound 4, half-maximal cytotoxic concentration: 56500 nM
Compound 4: the middle estimate sits 1.2-fold (0.09 log units) above what was measured; the measured number falls inside the stated range.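

In this assay, a second benzyl carrying both chlorine and trifluoromethyl on this sulfur again gives a number rather than a limit, with an at least 1.7-fold lower number from compound 2 to compound 4 (0.24 log units; that floor lies within the scatter) and an at least 1.7-fold lower number from compound 1 to compound 4 (0.24 log units; that floor lies within the scatter). The two arrangements of these substituents are not told apart, with a 1.1-fold higher number from compound 3 to compound 4 (0.02 log units; within the scatter). Compound 2 remains at a limit, so its step gives only a floor: the limit of > 100000 nM in this assay, at which 2 of the 4 values shown sit.

Going by these compounds, what a benzyl carrying only chlorine or only trifluoromethyl would give stays open. So does the reading for a benzyl carrying an amine or a carboxylic acid.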